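This account rests on a few compounds, and the source may have more. Where it says the series, first, only, none or still open, it means among the compounds named here.

Working notes on the series. Compound 1 `COc1ccc(C(=O)Oc2cc3c(cc2C)[C@@H](C(C)C)CC=C3C)cc1` gives 60.6% in a functional assay on PC-3 cells (Homo sapiens) for antiproliferative activity, read by sulforhodamine B assay, with a stated time of 48 h, tested at 50 uM (on this read-out lower numbers stand for less inhibition and higher numbers for more inhibition at the one concentration tested (going by the name of the read-out)), the lower of the two numbers at hand; compound 2 `Cc1cc2c(C(C)C)ccc(C)c2cc1OC(=O)c1ccc(C(F)(F)F)cc1` gives 100%, a gap beyond the usual scatter. Compound 3 `CC1=CC[C@H](C(C)C)c2cc(C)c(OC(=O)Nc3ccccc3)cc21` is not yet measured. Among the measured compounds shown here, the change from compound 1 is anilino in place of 4-methoxyphenyl on a carbonyl carbon; no pair of measured compounds shows this change, so its size is unknown. The expected step from compound 1 to compound 3 is a number 8.6 percentage points lower from compound 1 to compound 3 (within the scatter), a small decrease if any, since compound 1 sits at 60.6%. Compound 3 is therefore estimated at 52%, with a range from 25% to 85%.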

Compound 3, a percentage reported as inhibition, at one concentration (the size of the read-out at that concentration, not a potency): 93.2%
Compound 3: middle estimate off by 41.2 percentage points, on the low side, outside the stated range (above it).
By their numbers in this assay, from the lowest: compound 1; then compounds 3 and 2 (each within the scatter of the next).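

On a carbonyl carbon of the shared core, anilino in place of 4-methoxyphenyl gives a number 32.6 percentage points higher from compound 1 to compound 3 (beyond the scatter) in this assay, so the group held at this position can move the read-out well beyond the scatter. Among the compounds shown here, this is the first single-place step, and it shows the size and direction of this one change only. No measurement at hand accounts for the step.

The compounds shown leave open whether the step follows the nitrogen of anilino or the loss of the methoxy group. An unsubstituted phenyl or a benzylamino group on the same carbonyl carbon would separate the two.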